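Notes on amide nitrogen methylation, compound 1 to compound 3

The compounds below may be only part of what the source reports. "The series", "measured", "known", "first", "only" and "open" are said of these compounds alone.

Measured so far:
- compound 1 `O=C(Nc1cccc(-c2cccc(O)c2F)n1)c1ccc(F)c(O)c1`: 686 nM
- compound 2 `Nc1ccc2ccc(C(=O)c3ccc(F)c(O)c3)nc2c1`: 34 nM

Two compounds have numbers in an assay for binding affinity to 17-beta-hydroxysteroid dehydrogenase 14 (Homo sapiens), read by fluorescence, with a stated time of 15 min, in the presence of a further agent that is not named here; on this read-out lower numbers stand for stronger inhibition and higher numbers for weaker inhibition. Compound 1 gives 686 nM, the higher of the two numbers. Among the compounds with values here, compound 2 gives 34 nM, and the gap between the two values lies beyond the scatter; the two structures differ in more than one place, so no single step connects them and nothing is read into the gap beyond what the two values show.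

Compound 3 `CN(C(=O)c1ccc(F)c(O)c1)c1cccc(-c2cccc(O)c2F)n1` is the next compound to be measured in this assay. It differs from compound 1 in one place: methyl in place of hydrogen on an amide-type nitrogen. The amide hydrogen of compound 1 is replaced, and the rest of the structure is kept.

Within the data shown here, no measured pair shows the effect of this change, so the expectation rests on compound 1 alone. The step is expected to be a modest one, upward, with the number for compound 3 estimated somewhat higher than the value of compound 1, at 686 nM, though a result within the scatter is not excluded. In this assay compound 3 is expected to come in at 1500 nM, with a range from 500 nM to 6000 nM. This estimate means a step of a 2.2-fold higher number from compound 1 to compound 3 (0.34 log units; beyond the scatter).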

Compound 3, inhibition constant: 2030 nM
Beside the measured number, compound 3's estimate is 1.4-fold (0.13 log units) below it; measured number inside the range.
By their numbers in this assay, from the lowest: compound 2; then compound 1; then compound 3.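

In this assay, within the data shown here, methyl in place of hydrogen on the amide-type nitrogen gives a 3.0-fold higher number from compound 1 to compound 3 (0.47 log units; beyond the scatter) and is the first change that can be read as a single step. The amide hydrogen of compound 1 is thus a place where replacement alters the number, even with the rest of the structure kept, and the step runs toward weaker inhibition. The change does not abolish binding, since compound 3 still gives a defined value of 2030 nM in this assay and no measurement at hand says why the number rises.

This single step cannot separate the effect of removing the amide hydrogen from the effect of adding the methyl, and it gives no trend for this nitrogen. An ethyl group, or a longer chain ending in an amine or a carboxylic acid, on the same nitrogen would show whether the number keeps rising, levels off or turns back down with a different replacement for the amide hydrogen.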